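Ester oxygen substituent: cyclohexyl to propyl, cytotoxicity notes

A few compounds are considered here, and "the series" means these few. Any claim that something is new, unique, unknown or untested is made for them only; others in the source may bear on it.

For the measured compounds named here, compound 2 `Nc1ncnc2c1ncn2CC(O)C(=O)OC1CCCCC1` is the only member with a number in a functional assay on PRK cells (Oryctolagus cuniculus) for cytotoxicity (a lower number here means that less compound is tolerated, a higher number that more compound is tolerated), where compound 2 gives 100 ug/mL. Compound 1 `Nc1ncnc2c1ncn2CC(O)C(=O)OCCO` gives only a limit in this assay, namely > 400 ug/mL, as noted in the limit of > 400 ug/mL in this assay, at which 1 of the 2 values shown sits. Compound 3 `CCCOC(=O)C(O)Cn1cnc2c(N)ncnc21` differs from compound 2 by propyl in place of cyclohexyl on an oxygen next to a carbonyl group. Going by the values given here, the one measured step at this oxygen, an at least 4.0-fold lower number from compound 1 to compound 2 (0.60 log units; beyond the scatter), ran toward a cyclohexyl and lowered the tolerated number; the step to compound 3 runs away from cyclohexyl toward propyl, so a modest rise is expected, smaller than that step. For compound 3 the estimate is 200 ug/mL (range 100 ug/mL to 400 ug/mL), an expected step of a 2.0-fold higher number from compound 2 to compound 3 (0.30 log units; within the scatter).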

Compound 3, minimum cytotoxic concentration: 100 ug/mL
Beside the measured number, compound 3's estimate is 2.0-fold (0.30 log units) above it; the measured number falls inside the stated range.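

Propyl in place of cyclohexyl on an oxygen next to a carbonyl group gives no change at the digits printed from compound 2 to compound 3 (within the scatter) in this assay, so the ring and the larger carbon count do not separate these two compounds. Methyl in place of hydroxy on a saturated chain carbon gives an at least 4.0-fold lower number from compound 1 to compound 3 (0.60 log units; beyond the scatter), a single change that accounts for a step of the size first seen with cyclohexyl. Compound 1 stands at a limit, not a number: the limit of > 400 ug/mL in this assay, at which 1 of the 3 values shown sits.

As far as these compounds go, how far compound 1 truly lies from the other two stays open. Also open, from the compounds shown here alone, is whether an amine, a carboxylic acid or a longer chain ending in hydroxy on this oxygen would behave like compound 1.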